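Methoxy for methyl on the pyrazole N-aryl ring

The source may report more compounds than this note shows. Statements on the series, on what has been measured and on what is new or still open speak of the compounds shown alone.

Of the compounds shown here, two have been measured. Compound 1 `COc1ccc(-n2cc(NC(=O)c3ccc(NS(=O)(=O)c4ccccc4)cc3)cn2)cc1` gives, in a functional assay on A549 cells (Homo sapiens) for inhibition, read by MTT assay, with a stated time of 48 h (on this read-out higher numbers stand for weaker inhibition and lower numbers for stronger inhibition), a value of 85800 nM. Compound 2 `Cc1ccc(-n2cc(NC(=O)c3ccc(NS(=O)(=O)c4ccc(Cl)cc4)cc3)cn2)cc1` gives in this assay a value of 22000 nM, the lower of the two numbers, and the gap to compound 1 lies beyond the scatter. The two differ in more than one place, so no single change can be credited.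

Compound 3 `COc1ccc(-n2cc(NC(=O)c3ccc(NS(=O)(=O)c4ccc(Cl)cc4)cc3)cn2)cc1` is not yet measured. Compared with compound 2 the change is methoxy in place of methyl on an aromatic carbon. The sulfonyl part of compound 3 matches compound 2, while the methoxy group is shared with compound 1, whose value in this assay is the higher one. With the effect of each change unresolved, a modest shift is expected, more likely towards a higher number, and the step of a 1.6-fold higher number from compound 2 to compound 3 (0.20 log units; within the scatter) is estimated to stay near the scatter. Compound 3 is thus expected to give about 35000 nM in this assay, within a range from 15000 nM to 90000 nM.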

Compound 3, half-maximal inhibitory concentration: 61000 nM
Estimate against measurement, compound 3: 1.7-fold (0.24 log units) below; the range from low to high includes it.
By their numbers in this assay, from the lowest: compound 2; then compounds 3 and 1 (each within the scatter of the next).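

In this assay methoxy in place of methyl on an aromatic carbon gives a 2.8-fold higher number from compound 2 to compound 3 (0.44 log units; beyond the scatter) with the sulfonyl part held, so this position responds to the change from 4-methylphenyl to 4-methoxyphenyl. With the methoxy held, chloro in place of hydrogen on an aromatic carbon gives a 1.4-fold lower number from compound 1 to compound 3 (0.15 log units; within the scatter) in the same assay, so the gap between compound 1 and compound 2 now sits mainly with the methoxy and methyl exchange, at least where chloro is added to the methoxy compound. No measurement at hand explains either step.

Whether chloro reads the same alongside 4-methylphenyl stays open, as the compounds shown give that step only with methoxy. Also open, on these data alone, is how this position would respond to an amine, a carboxylic acid or a longer chain.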